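Methoxy on the sulfonamide phenyl of compound 3

A few compounds are considered here, and "the series" means these few. Any claim that something is new, unique, unknown or untested is made for them only; others in the source may bear on it.

Compound 1 `CN(c1ccccc1)S(=O)(=O)C1CC2OC1C(c1ccc(NC(=O)CCCCCCC(=O)O)cc1)=C2c1ccc(O)cc1` gives > 100000 nM in an ADME assay on Vero cells (Chlorocebus sabaeus) for antiproliferative activity, read by MTT assay, with a stated time of 72 h (a lower number here means a stronger inhibitor, a higher number a weaker inhibitor), which is a limit and not a number. Compound 2 `CN(c1cccc2ccccc12)S(=O)(=O)C1CC2OC1C(c1ccc(NC(=O)CCCCCCC(=O)O)cc1)=C2c1ccc(O)cc1` gives > 100000 nM in this assay, again a limit. Compound 3 `CCN(c1ccccc1)S(=O)(=O)C1CC2OC1C(c1ccc(NC(=O)CCCCCCC(=O)O)cc1)=C2c1ccc(O)cc1` gives > 100000 nM, also a limit, so the starting point has no number of its own. Going by the values given here, the series so far stands at the limit of > 100000 nM in this assay, at which 3 of the 3 values shown sit.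

Compound 4 `CCN(c1cccc(OC)c1)S(=O)(=O)C1CC2OC1C(c1ccc(NC(=O)CCCCCCC(=O)O)cc1)=C2c1ccc(O)cc1` carries methoxy in place of hydrogen on an aromatic carbon, which turns ethyl(phenyl)amino into ethyl(3-methoxyphenyl)amino.

Among the compounds with values here, three measured steps touch the groups on the sulfonamide nitrogen: a step that the two limits leave unreadable from compound 1 to compound 2, a step that the two limits leave unreadable from compound 1 to compound 3 and a step that the two limits leave unreadable from compound 2 to compound 3. None offers a size to carry over, and none involves a methoxy group. With no readable precedent, no direction can be assigned. The expected step, a number no higher from compound 3 to compound 4 (the limit leaves the size open), is none beyond the scatter, and another limit is the most likely report. For compound 4 the estimate is 100000 nM, with an expected range of 50000 nM to 200000 nM.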

Compound 4, half-maximal inhibitory concentration: > 100000 nM
Compound 4 was reported as a limit (the forecaster's own chance of this, stated with the estimate: 85%); the middle value lies on the limit itself.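

Compound 4 is reported only as a limit, as are compound 1, compound 2 and compound 3, so none of the steps to compound 4 can be read. The compounds shown leave open whether any group on the sulfonamide nitrogen changes the result in this assay: the limit of > 100000 nM in this assay, at which 4 of the 4 values shown sit.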